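Swapping a para substituent on the benzamide ring

This account rests on a few compounds, and the source may have more. Where it says the series, first, only, none or still open, it means among the compounds named here.

Of the compounds shown here, three sharing one core have been measured so far. Compound 1 `O=C(Nc1cccc(-c2oc3cc(-c4ccc(F)cc4)ccc3c(=O)c2O)c1)c1ccc(C(F)(F)F)cc1` gives 19400 nM in a functional assay on A549 cells (Homo sapiens) for antiproliferative activity, read by CCK-8 assay, with a stated time of 72 h; on this read-out higher numbers stand for weaker inhibition and lower numbers for stronger inhibition. Compound 2 `O=C(Nc1cccc(-c2oc3cc(-c4ccc(F)cc4)ccc3c(=O)c2O)c1)c1ccc(Br)cc1` gives 13500 nM in the same assay, and compound 3 `Cc1cc(C)cc(C(=O)Nc2cccc(-c3oc4cc(-c5ccc(F)cc5)ccc4c(=O)c3O)c2)c1` gives 3740 nM. On these numbers compound 2 stands second highest of three: its distance to compound 1 is within the scatter, a 1.4-fold lower number from compound 1 to compound 2 (0.16 log units; within the scatter), while the change to compound 3 is a clear move toward stronger inhibition, a 3.6-fold lower number from compound 2 to compound 3 (0.56 log units; beyond the scatter).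

Compound 4 `N#Cc1ccc(C(=O)Nc2cccc(-c3oc4cc(-c5ccc(F)cc5)ccc4c(=O)c3O)c2)cc1` has not yet been measured. It differs from compound 2 in one place: cyano in place of bromo on an aromatic carbon. The change sits on an aromatic carbon of a six-membered aromatic ring of carbon only, para to a large group.

Among the compounds with values here, only one measured step bears directly on this, the exchange of one group on that aromatic carbon for another from compound 1 to compound 2, which stayed within the scatter. The steps to compound 3 rearranged the whole ring and so say little about a single exchange. The expectation therefore is a step of no clear size, a 1.1-fold lower number from compound 2 to compound 4 (0.05 log units; within the scatter). Compound 4 is estimated at 12000 nM, with a range from 4500 nM to 32000 nM.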

Compound 4, half-maximal inhibitory concentration: 2360 nM
The estimate for compound 4 lay 5.1-fold (0.71 log units) above the measured number; measured number below the stated range.
By their numbers in this assay, from the lowest: compounds 4 and 3 (each within the scatter of the next); then compounds 2 and 1 (each within the scatter of the next).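

In this assay, within the data shown here, the group on this aromatic carbon turns out to matter: a 5.7-fold lower number from compound 2 to compound 4 (0.76 log units; beyond the scatter) shows that cyano in place of bromo moves the number beyond the scatter, and an 8.2-fold lower number from compound 1 to compound 4 (0.91 log units; beyond the scatter) does the same for cyano in place of trifluoromethyl, whereas the only earlier exchange at this spot, a 1.4-fold lower number from compound 1 to compound 2 (0.16 log units; within the scatter), stayed within the scatter and could have suggested that the position was insensitive. A small exchange of one group also lands level with a change that reworks the substituents on the ring, since a 1.6-fold lower number from compound 3 to compound 4 (0.20 log units; within the scatter) lies within the scatter, so the 4-cyanophenyl and 3,5-dimethylphenyl amides cannot be told apart on these numbers. Nothing measured here explains why cyano separates from bromo and trifluoromethyl in this way.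

With only three groups shown on this aromatic carbon, the compounds leave open how an amine, a carboxylic acid or a methoxy group there would read. They also leave open whether cyano in place of bromo would give a similar step on any core other than the shared core.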